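Iodo benzyl ester: expectation for compound 4

The compounds below may be only part of what the source reports. "The series", "measured", "known", "first", "only" and "open" are said of these compounds alone.

Values in a functional assay on MKN-28 cells (Homo sapiens) for cytotoxicity, read by MTT assay (a lower number here means a stronger inhibitor, a higher number a weaker inhibitor), so far:
- compound 1 `C=C1C(=O)[C@]23C[C@@]1(Cl)CC[C@H]2[C@@]12C=CC(=O)[C@](C)(C(=O)O1)[C@H]2[C@@H]3C(=O)OCc1ccccc1` gives 6800 nM
- compound 2 `C=C1C(=O)[C@]23C[C@@]1(O)CC[C@H]2[C@@]12C=CC(=O)[C@](C)(C(=O)O1)[C@H]2[C@@H]3C(=O)OCc1ccccc1` gives 2500 nM
- compound 3 `C=C1C(=O)[C@]23C[C@@]1(I)CC[C@H]2[C@@]12C=CC(=O)[C@](C)(C(=O)O1)[C@H]2[C@@H]3C(=O)OC` gives 6700 nM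

Compound 3 lies within the scatter of compound 1, and both stand above compound 2. Compound 4 `C=C1C(=O)[C@]23C[C@@]1(I)CC[C@H]2[C@@]12C=CC(=O)[C@](C)(C(=O)O1)[C@H]2[C@@H]3C(=O)OCc1ccccc1` turns methoxycarbonyl into benzyloxycarbonyl, with phenyl in place of hydrogen on a saturated chain carbon bound to an oxygen next to a carbonyl group as the difference: phenyl in place of hydrogen on a saturated chain carbon bound to an oxygen next to a carbonyl group. Among the measured compounds shown here, the only measured step, a 2.7-fold lower number from compound 1 to compound 2 (0.43 log units; beyond the scatter), swaps chloro for hydroxy and keeps benzyloxycarbonyl, so it does not test this change. Compound 1 carries benzyloxycarbonyl and gives 6800 nM, close to the value of compound 3. No change beyond the scatter is expected in this assay, and the estimate is a 1.1-fold lower number from compound 3 to compound 4 (0.05 log units; within the scatter) as the step. For compound 4 the expected value is 6000 nM, with an estimated range of 2500 nM to 14000 nM.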

Compound 4, half-maximal inhibitory concentration: 3000 nM
Compound 4: the middle estimate sits 2.0-fold (0.30 log units) above what was measured; low and high end bracket the measured number.
By their numbers in this assay, from the lowest: compounds 2 and 4 (each within the scatter of the next); then compounds 3 and 1 (each within the scatter of the next).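

In this assay, the ester position responds on the iodo compounds: methoxycarbonyl to benzyloxycarbonyl gives a 2.2-fold lower number from compound 3 to compound 4 (0.35 log units; beyond the scatter). With benzyloxycarbonyl held, the halogen on the saturated ring carbon also counts, with iodo in place of chloro giving a 2.3-fold lower number from compound 1 to compound 4 (0.36 log units; beyond the scatter), while iodo in place of hydroxy gives only a 1.2-fold higher number from compound 2 to compound 4 (0.08 log units; within the scatter), so the earlier separation of hydroxy from halogen does not hold for iodo. No measurement offered here accounts for these steps.

Still open, from the compounds shown here alone, is whether a carboxylic acid or a longer chain at the ester position would follow benzyl or methyl. An amine on the saturated ring carbon is equally untested in the compounds shown.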